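A few compounds are considered here, and "the series" means these few. Any claim that something is new, unique, unknown or untested is made for them only; others in the source may bear on it.

Measured so far:
compound 1 `Cc1cccc(S(=O)(=O)c2ccc(CNC(=O)c3cc4cnccc4[nH]3)cc2)c1` — 49%
compound 2 `O=C(NCc1ccc(S(=O)(=O)c2ccccc2)cc1)c1cnc2nccn2c1` — 60%

Two compounds have been run in an ADME assay on microsomes from liver (Homo sapiens) for metabolic stability, read by LC-MS, with a stated time of 30 min, tested at 1 uM; a lower number here means that less of the compound is left, a higher number that more of the compound is left. Compound 2 gives 60%, the higher of the two numbers; its nearest neighbour, compound 1, gives 49%, a gap that lies beyond the scatter. For the measured compounds named here, no pair that differs in a single place has been measured, so no step can be read from the data yet.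

Compound 3 `O=C(NCc1ccc(S(=O)(=O)c2ccccc2)cc1)c1cc2cnccc2[nH]1` is the next candidate. It keeps the shared core of compound 2 and changes only the group on the carbonyl carbon: a group of 9 heavy atoms (7 carbon, 2 nitrogen; one five-membered aromatic ring with 1 hetero atom, one six-membered aromatic ring with 1 hetero atom) in place of a group of 9 heavy atoms (6 carbon, 3 nitrogen; one five-membered aromatic ring with 2 hetero atoms, one six-membered aromatic ring with 2 hetero atoms), on a carbonyl carbon. Going by the values given here, the group that enters is the one carried by compound 1, which gives 49% in this assay. On that basis a downward step from compound 2 to compound 3 is expected in this assay, of modest size, roughly at the edge of the scatter rather than far beyond it. The estimate for compound 3 is 50%, with a range of 35% to 65%, corresponding to an expected step of a number 10 percentage points lower from compound 2 to compound 3 (within the scatter).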

Compound 3, percent of the compound remaining: 75%
Compound 3: the middle estimate sits 25 percentage points below what was measured; the whole stated range lies below it.
By their numbers in this assay, from the lowest: compound 1; then compound 2; then compound 3.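

In this assay the group on the carbonyl carbon now has a direct reading: the group of 9 heavy atoms with 7 carbon and 2 nitrogen, in place of the group of 9 heavy atoms with 6 carbon and 3 nitrogen, gives a rise (a number 15 percentage points higher from compound 2 to compound 3 (beyond the scatter)), so the number responds to the change at this place and the group carried by compound 1 does not by itself hold a compound at a low number. With that group kept, hydrogen in place of methyl on an aromatic carbon also gives a rise (a number 26 percentage points higher from compound 1 to compound 3 (beyond the scatter)), so a second place in these compounds moves the number beyond the scatter. No measurement shown bears on why either step occurs.

From the compounds shown here alone, it remains open whether hydrogen in place of methyl on the aromatic carbon gives a similar step when the carbonyl carbon carries the group of compound 2. Also open, going by these compounds, is how fluorine, chlorine or methoxy on that aromatic carbon would read, and whether a simple phenyl group on the carbonyl carbon would fall with compound 2 or with compound 3.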